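The compounds below may be only part of what the source reports. "The series", "measured", "known", "first", "only" and "open" are said of these compounds alone.

Among the measured compounds shown here, compound 3, `CCCCCCCCC(C)OC(=O)NC(=O)Nc1c(C(C)C)cccc1C(C)C`, stands second highest of the three numbers so far in an assay on microsomes from intestine for inhibition of acyl-CoA:cholesterol acyltransferase (Oryctolagus cuniculus) (a higher number here means a weaker inhibitor, a lower number a stronger inhibitor), where compound 3 gives 750 nM. Its nearest neighbour is compound 2, `CCCCCCCC(C)OC(=O)NC(=O)Nc1c(C(C)C)cccc1C(C)C`, which in this assay gives 390 nM. Compound 1, `CCCCCCCCCCCCCCN(C)C(=O)NC(=O)Nc1c(C(C)C)cccc1C(C)C`, carries a long tetradecyl chain on a urea nitrogen and in this assay compound 1 gives 1700 nM, a higher number than either carbamate.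

Compound 4, `CCCCCCCCCCCCCCC(C)OC(=O)NC(=O)Nc1c(C(C)C)cccc1C(C)C`, differs from compound 3 by hexyl in place of hydrogen on a saturated chain carbon, nine bonds along the chain from an oxygen next to a carbonyl group. For the measured compounds named here, the only measured step that bears on chain extension is a 1.9-fold higher number from compound 2 to compound 3 (0.28 log units; within the scatter), a small change for a single added carbon. Going by the values given here, no step shows the effect of adding six carbons at once; the only hint is the higher number of compound 1 with its long chain, though compound 1 differs in more than the chain. The step is therefore expected to run toward a higher number, by a 1.6-fold higher number from compound 3 to compound 4 (0.20 log units; within the scatter). For compound 4 the estimate in this assay is 1200 nM, with a range from 400 nM to 3500 nM.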

Compound 4, half-maximal inhibitory concentration: 6800 nM
Beside the measured number, compound 4's estimate is 5.7-fold (0.75 log units) below it; the measured number lies above the stated range.
By their numbers in this assay, from the lowest: compounds 2 and 3 (each within the scatter of the next); then compound 1; then compound 4.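

In this assay, lengthening this chain now has a clear cost: hexyl in place of hydrogen, on a saturated chain carbon nine bonds along the chain from an oxygen next to a carbonyl group, gives a 9.1-fold higher number from compound 3 to compound 4 (0.96 log units; beyond the scatter). Measured from the shorter carbamate, heptyl in place of hydrogen gives a 17-fold higher number from compound 2 to compound 4 (1.24 log units; beyond the scatter), whereas the single added methyl gave only a 1.9-fold higher number from compound 2 to compound 3 (0.28 log units; within the scatter), so the earlier step did not reveal how far the number could rise with chain length. Nothing available here explains this rise.

The compounds shown leave open whether the number climbs steadily or jumps at some length, which a propyl group on the same carbon could help to settle. They also leave open how a shorter chain, or a chain ending in an amine or a carboxylic acid, would behave.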